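The compounds below may be only part of what the source reports. "The series", "measured", "known", "first", "only" and "open" are said of these compounds alone.

Measured in a functional assay on SW 1116 cells (Homo sapiens) for antiproliferative activity, read by MTT assay, with a stated time of 24 h; on this read-out lower numbers stand for stronger inhibition and higher numbers for weaker inhibition:
- compound 1 `Sc1nnc(-c2ccc3c(c2)OCCO3)n1-c1ccccc1`: 38400 nM
- compound 2 `O=[N+]([O-])c1cccc(CSc2nnc(-c3ccc4c(c3)OCCO4)n2-c2ccccc2)c1`: 7590 nM

Of these two, compound 2 has the lower number. Compound 3 `Cc1ccc(CSc2nnc(-c3ccc4c(c3)OCCO4)n2-c2ccccc2)cc1` is the next to be read, with 4-methylphenyl in place of 3-nitrophenyl on a saturated chain carbon bound to a sulfur. Going by the values given here, only one measured step bears on this, a 5.1-fold lower number from compound 1 to compound 2 (0.70 log units; beyond the scatter). Among the compounds with values here, no measured compound compares two benzyl groups, so that step only loosely bounds the change. Compound 3 keeps a benzyl on the sulfur, so a smaller step in this assay, towards a slightly higher number, is expected. The estimated step is a 1.3-fold higher number from compound 2 to compound 3 (0.12 log units; within the scatter). Compound 3 is expected at 10000 nM, within an estimated range of 4500 nM to 24000 nM.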

Compound 3, half-maximal inhibitory concentration: 16200 nM
Estimate against measurement, compound 3: 1.6-fold (0.21 log units) below; measured number inside the range.
By their numbers in this assay, from the lowest: compound 2; then compound 3; then compound 1.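

In this assay the position on the sulfur now separates two benzyl groups: 4-methylphenyl in place of 3-nitrophenyl gives a 2.1-fold higher number from compound 2 to compound 3 (0.33 log units; beyond the scatter), so the aryl group on this saturated chain carbon affects the read-out. The gain over the free sulfur is not confined to 3-nitrobenzyl, since 4-methylbenzyl also gives a 2.4-fold lower number from compound 1 to compound 3 (0.37 log units; beyond the scatter). Nothing measured explains the difference between these two groups.

The nitro-to-methyl swap and the move from 3 to 4 on the ring remain unseparated here. Plain benzyl, 4-nitrobenzyl and a longer phenylethyl chain on the sulfur remain open.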